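Pyridin-3-yl in place of 2-methoxyphenyl on the carbonyl carbon

The source may report more compounds than this note shows. Statements on the series, on what has been measured and on what is new or still open speak of the compounds shown alone.

Measured compounds in an assay on MDA-MB-231 cells for displacement of a labelled ligand from C-X-C chemokine receptor type 4 (Homo sapiens), read by fluorescence and microscopy, with stated times of 10 min and 30 min; on this read-out higher numbers stand for an effect only at larger amounts of compound and lower numbers for an effect already at smaller amounts:
Compound 1, `COc1ccccc1C(=O)NCc1ccc(CNS(=O)(=O)c2ccc([N+](=O)[O-])cc2)cc1`: compound 1 gives 100 nM.
Compound 2, `COc1ccccc1C(=O)NCc1ccc(CNS(=O)(=O)c2ccccc2C)cc1`: compound 2 gives 1000 nM.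
Compound 3, `COc1ccccc1C(=O)NCc1ccc(CNS(=O)(=O)c2ccccc2Cl)cc1`: compound 3 gives 100 nM.

Compound 2 has the highest number of the three, while the other two agree with each other: a 10-fold higher number from compound 1 to compound 2 (1.00 log units; beyond the scatter), and a 10-fold lower number from compound 2 to compound 3 (1.00 log units; beyond the scatter). Both of these steps alter the group on the sulfonyl sulfur. Compound 4, `Cc1ccccc1S(=O)(=O)NCc1ccc(CNC(=O)c2cccnc2)cc1`, instead changes the other end of the shared core: pyridin-3-yl in place of 2-methoxyphenyl on a carbonyl carbon. No measured step touches the carbonyl side, so nothing among these compounds indicates how the number should move. The expectation therefore rests on compound 2 alone and carries a wide range: the estimated step is no change at the digits printed from compound 2 to compound 4 (within the scatter). Compound 4 is expected to give about 1000 nM, between 200 nM and 5000 nM.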

Compound 4, effective concentration (reported as EC, without a stated level of effect): 1000 nM
Estimate against measurement, compound 4: no gap at the digits printed; measured number inside the range.
By their numbers in this assay, from the lowest: compounds 1 and 3 (each within the scatter of the next); then compounds 2 and 4 (each within the scatter of the next).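

The carbonyl side of the shared core now has its first measured step: there is no change at the digits printed from compound 2 to compound 4 (within the scatter) when pyridin-3-yl replaces 2-methoxyphenyl. With 2-methylphenyl kept on the sulfonyl sulfur, this position takes a ring with one hetero atom and fewer heavy atoms without a shift in the number. No available data explain this result.

Going by these compounds, it remains open whether the swap behaves the same way with 4-nitrophenyl or 2-chlorophenyl on the sulfonyl sulfur, where the numbers are lower. Also open, on these data alone, is what a carboxylic acid or a longer alkyl chain would do on the carbonyl carbon.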